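Ester variation on a shared core in a cytotoxicity assay

This account rests on a few compounds, and the source may have more. Where it says the series, first, only, none or still open, it means among the compounds named here.

Measured compounds:
Compound 1, `CC(C)C(=O)OC1CCC(CN2CCN(c3cc(=O)c4cc(C(F)(F)F)cc([N+](=O)[O-])c4s3)CC2)CC1`, in an ADME assay on Vero cells (Chlorocebus sabaeus) for cytotoxicity, read by MTT assay, with a stated time of 48 h (a higher number here means a weaker inhibitor, a lower number a stronger inhibitor), gives > 64 ug/mL, a limit of the assay.
Compound 2, `C=CC(=O)OC1CCC(CN2CCN(c3cc(=O)c4cc(C(F)(F)F)cc([N+](=O)[O-])c4s3)CC2)CC1`, in this assay gives > 64 ug/mL, likewise a limit.
Compound 3, `O=C(OC1CCC(CN2CCN(c3cc(=O)c4cc(C(F)(F)F)cc([N+](=O)[O-])c4s3)CC2)CC1)c1ccc(F)cc1`, in this assay gives > 64 ug/mL, again a limit.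

Compound 1 stands only at a limit in this assay, and the two further values are limits as well. The steps a step that the two limits leave unreadable from compound 1 to compound 2, a step that the two limits leave unreadable from compound 1 to compound 3 and a step that the two limits leave unreadable from compound 2 to compound 3 are therefore not readable in size; all three values sit at the limit of > 64 ug/mL in this assay, at which 3 of the 3 values shown sit. The unmeasured compound 4, `COc1ccc(C(=O)OC2CCC(CN3CCN(c4cc(=O)c5cc(C(F)(F)F)cc([N+](=O)[O-])c5s4)CC3)CC2)cc1`, differs from compound 1 in one place: 4-methoxyphenyl in place of isopropyl on a carbonyl carbon. Among the measured compounds shown here, the closest measured step is the one from compound 1 to compound 3, where a 4-fluorophenyl took the place of the isopropyl on the carbonyl carbon, and the value stayed at the limit. For the measured compounds named here, no measured step sets a direction or a size for the change to compound 4, so compound 4 is expected to stay at the limit in this assay, the step of a number no higher from compound 1 to compound 4 (the limit leaves the size open) being the expected change. Compound 4 is estimated at 64 ug/mL in this assay, within 32 ug/mL to 128 ug/mL.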

Compound 4, half-maximal inhibitory concentration: > 64 ug/mL
Compound 4: a limit, no number; the forecaster's own chance of this, stated with the estimate: 85%; the middle value sits exactly at the limit.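

In this assay compound 4 gives > 64 ug/mL as a limit of the assay. Its steps to compound 1, compound 2 and compound 3 therefore cannot be read: the limit of > 64 ug/mL in this assay, at which 4 of the 4 values shown sit. The compounds shown leave open the concentration at which any of these four esters reaches half-maximal inhibition, and so how they differ.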